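This account rests on a few compounds, and the source may have more. Where it says the series, first, only, none or still open, it means among the compounds named here.

In a functional assay on HepG2 cells (Homo sapiens) for inhibition, read by MTT assay, with a stated time of 72 h (on this read-out higher numbers stand for weaker inhibition and lower numbers for stronger inhibition), two compounds built on a shared core have been measured. Compound 1 `CN(C(=O)NC(=O)c1cccc(C(F)(F)F)c1)c1nc(C(F)(F)F)c(C(=O)N/N=C/c2ccc(C(F)(F)F)cc2)s1` gives 7.71 ug/mL. For the measured compounds named here, compound 2 `CN(C(=O)NC(=O)c1cccc(C(F)(F)F)c1)c1nc(C(F)(F)F)c(C(=O)N/N=C/c2ccccc2C(F)(F)F)s1` gives 10.4 ug/mL, the higher of the two numbers, though the only measured step, a 1.3-fold higher number from compound 1 to compound 2 (0.13 log units; within the scatter), lies within the scatter, so the two compounds cannot be set in order. Compound 3 `CN(C(=O)NC(=O)c1ccc(Cl)cc1Cl)c1nc(C(F)(F)F)c(C(=O)N/N=C/c2ccccc2C(F)(F)F)s1` has not yet been measured in this assay. It differs from compound 2 in one place: 2,4-dichlorophenyl in place of 3-(trifluoromethyl)phenyl on a carbonyl carbon. Going by the values given here, no measured step touches this carbonyl-bound ring; the one step known, from compound 1 to compound 2, changes the ring on the carbon with a double bond to nitrogen and was within the scatter. Nothing in the data therefore points in either direction, and the expected step of no change at the digits printed from compound 2 to compound 3 (within the scatter) is none beyond the scatter. Compound 3 is estimated at 10.4 ug/mL, with a range from 5.2 ug/mL to 21 ug/mL.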

Compound 3, half-maximal inhibitory concentration: 10.7 ug/mL
Beside the measured number, compound 3's estimate is 1.0-fold (0.01 log units) below it; measured number inside the range.
By their numbers in this assay, from the lowest: compounds 1, 2 and 3 (each within the scatter of the next).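

In this assay, for the compounds shown here, the ring on the carbonyl carbon, which no earlier step touched, now has a step of its own, a 1.0-fold higher number from compound 2 to compound 3 (0.01 log units; within the scatter), and this is the first reading at this position. On a carbonyl carbon whose other neighbours are an amide-type nitrogen, 2,4-dichlorophenyl and 3-(trifluoromethyl)phenyl cannot be told apart on this read-out, at least alongside 2-(trifluoromethyl)phenyl at the other end of the molecule. No measurement shown here explains this result.

The compounds leave open whether a ring carrying an amine or a carboxylic acid, or a longer alkyl chain in place of the ring, would shift the number beyond the scatter at this position. They also leave open whether 2,4-dichlorophenyl would read the same alongside 4-(trifluoromethyl)phenyl.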